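This account rests on a few compounds, and the source may have more. Where it says the series, first, only, none or still open, it means among the compounds named here.

In a functional assay on HEK293 cells for agonist activity at melatonin receptor type 1B (Homo sapiens), read by calcium flux (on this read-out higher numbers stand for an effect only at larger amounts of compound and lower numbers for an effect already at smaller amounts), compound 1 `COc1cc2c(CO)coc2cc1C` gives 520000 nM. Compound 2 `CCN(CC)Cc1coc2cc(C)c(OC)cc12` gives 360000 nM in this assay, and compound 3 `COc1cc2c(CN3CCCC3)coc2cc1C` gives 350000 nM. Compound 3 therefore carries the smallest of the three numbers, yet its distance to each of the other two lies within the scatter, so the three compounds cannot be told apart on this read-out. The move to compound 4 `COc1cc2c(CN3CCNCC3)coc2cc1C` brings (piperazin-1-yl in place of pyrrolidin-1-yl on a saturated chain carbon bound to an aromatic carbon). The measured steps that bear on this exchange all swap a group at the same place: a 1.4-fold lower number from compound 1 to compound 2 (0.16 log units; within the scatter), a 1.5-fold lower number from compound 1 to compound 3 (0.17 log units; within the scatter) and a 1.0-fold lower number from compound 2 to compound 3 (0.01 log units; within the scatter), none of which shifted the number beyond the scatter. The step of no change at the digits printed from compound 3 to compound 4 (within the scatter) is therefore expected to stay within the scatter too. Compound 4 is estimated at 350000 nM, with a range from 150000 nM to 800000 nM.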

Compound 4, half-maximal effective concentration: 380000 nM
Compound 4: middle estimate off by 1.1-fold (0.04 log units), on the low side; the measured number falls inside the stated range.
By their numbers in this assay, from the lowest: compounds 3, 2, 4 and 1 (each within the scatter of the next).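

Among the amines at this place, piperazin-1-yl is the first to bring a hydrogen-bond donor and a six-membered ring, and in this assay the exchange for pyrrolidin-1-yl gives a 1.1-fold higher number from compound 3 to compound 4 (0.04 log units; within the scatter). The other two exchanges give a 1.1-fold higher number from compound 2 to compound 4 (0.02 log units; within the scatter) and a 1.4-fold lower number from compound 1 to compound 4 (0.14 log units; within the scatter), so the four groups on this saturated chain carbon cannot be told apart on this read-out. Nothing given here explains why they read alike. The compounds shown leave open whether a carboxylic acid or a longer chain at this place would move the number beyond the scatter.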